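Swapping the saturated group on the triple bond: compound 4

The source may report more compounds than this note shows. Statements on the series, on what has been measured and on what is new or still open speak of the compounds shown alone.

Compound 1, `O=c1[nH]c(=O)n(CCC(CO)CO)cc1-c1ccco1`: in a functional assay on SW-620 cells (Homo sapiens) for antiproliferative activity, read by MTT assay, with a stated time of 72 h (a lower number here means a stronger inhibitor, a higher number a weaker inhibitor), compound 1 gives > 100000 nM, which is a limit of the assay.
Compound 2, `CC(=O)OCC(CCn1cc(C#CCc2ccccc2)c(=O)n(C(=O)c2ccccc2)c1=O)COC(C)=O`: in this assay compound 2 gives 36400 nM.
Compound 3, `CC(=O)OCC(CCn1cc(C#CC2CC2)c(=O)n(C(=O)c2ccccc2)c1=O)COC(C)=O`: in this assay compound 3 gives > 100000 nM, which is a limit of the assay.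

Compound 3 therefore stands at the limit of > 100000 nM in this assay, at which 2 of the 3 values shown sit, so only a lower bound on its number is known. Within the data shown here, the one measured step that touches the group on the triple bond is an at least 2.7-fold higher number from compound 2 to compound 3 (0.43 log units; beyond the scatter), a move from an aromatic-bearing group to a small saturated ring that pushed the value out to the limit.

Compound 4, `CC(=O)OCC(CCn1cc(C#CC(C)(C)C)c(=O)n(C(=O)c2ccccc2)c1=O)COC(C)=O`, differs from compound 3 by tert-butyl in place of cyclopropyl on a triple-bonded carbon. No measured step compares two saturated groups at this position, so the expectation rests on compound 3 alone; the change keeps a compact saturated substituent and gives no measured reason to expect a return toward the value of compound 2. The step that the limit leaves unreadable from compound 3 to compound 4 is expected to lie within the scatter, with the limit likely reported again. Compound 4 is estimated at 120000 nM, in the range 40000 nM to 300000 nM.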

Compound 4, half-maximal inhibitory concentration: > 100000 nM
Compound 4: only a limit was reported; the forecaster's own chance of this, stated with the estimate: 70%; the middle value does not contradict the limit.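

In this assay, replacing benzyl with tert-butyl on a triple-bonded carbon gives an at least 2.7-fold higher number from compound 2 to compound 4 (0.43 log units; beyond the scatter), so the move seen with cyclopropyl recurs with a saturated group that has no ring. Among the three compounds with this substituent varied, only compound 2 now has a number rather than a limit. The step from compound 3 to compound 4 cannot be read, as both values are limits, and the limit now dominates the compounds shown: the limit of > 100000 nM in this assay, at which 3 of the 4 values shown sit.

Going by these compounds, whether the phenyl ring of benzyl or merely a longer substituent supports the value of compound 2 stays open, and a phenyl set directly on the triple bond or a straight hexyl chain would separate the two. Any order between cyclopropyl and tert-butyl also stays hidden behind the limit.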